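Chloro in place of cyclohexyl: outlook for compound 4

This account rests on a few compounds, and the source may have more. Where it says the series, first, only, none or still open, it means among the compounds named here.

Compound 1 `O=C1NCCN1c1ccc(S(=O)(=O)Nc2ccc(C3CCCCC3)cc2)cc1` sits at a limit in a functional assay on HT-29 cells (Homo sapiens) for antiproliferative activity, read by sulforhodamine B assay, with a stated time of 48 h; on this read-out higher numbers stand for weaker inhibition and lower numbers for stronger inhibition: compound 1 is reported only as > 1000 nM, a limit of the assay and not a number. Compound 3 `O=C1NCCN1c1ccc(S(=O)(=O)Nc2ccccc2)cc1` gives 280 nM in this assay, and compound 2 `Cc1cccc(NS(=O)(=O)c2ccc(N3CCNC3=O)cc2)c1` gives 110 nM. Compound 4 `O=C1NCCN1c1ccc(S(=O)(=O)Nc2ccc(Cl)cc2)cc1` differs from compound 1 in one respect: chloro in place of cyclohexyl on an aromatic carbon. Among the compounds with values here, two measured steps bear on it. The step of an at least 3.5-fold lower number from compound 1 to compound 3 (0.55 log units; beyond the scatter) shows that taking the cyclohexyl away already helps, though compound 1 stands at the limit of > 1000 nM in this assay, at which 1 of the 3 values shown sits, and so the true size of that step is open on one side. The step of a 2.5-fold higher number from compound 2 to compound 3 (0.41 log units; beyond the scatter) shows that a single small group on that aromatic carbon, methyl, is better than hydrogen. Chloro is also a single heavy atom on that carbon, so compound 4 is expected to land in the region of compound 2 and compound 3, with an expected step of an at least 5.0-fold lower number from compound 1 to compound 4 (0.69 log units; beyond the scatter). For compound 4 the estimate in this assay is 200 nM, with a range of 80 nM to 600 nM.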

Compound 4, half-maximal inhibitory concentration: 220 nM
Estimate against measurement, compound 4: 1.1-fold (0.04 log units) below; the range from low to high includes it.
By their numbers in this assay, from the lowest: compounds 2, 4 and 3 (each within the scatter of the next, the first and the last beyond it). At a limit, above all of these: compound 1.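

In this assay, chloro on this aromatic carbon avoids the loss that goes with cyclohexyl, with an at least 4.5-fold lower number from compound 1 to compound 4 (0.65 log units; beyond the scatter). As far as these compounds go, compound 1 is reported only as > 1000 nM, a limit of the assay and not a number, so the full size of that step stays open: the limit of > 1000 nM in this assay, at which 1 of the 4 values shown sits. Replacing hydrogen with chloro gives a 1.3-fold lower number from compound 3 to compound 4 (0.10 log units; within the scatter), and the change to 4-chlorophenyl from 3-methylphenyl gives a 2.0-fold higher number from compound 2 to compound 4 (0.30 log units; within the scatter), so compound 4 cannot be separated from either compound 3 or compound 2.

The compounds shown do not settle how large a group this carbon can carry before activity falls away, as nothing lies between chloro and cyclohexyl. An ethyl or methoxy group here would narrow that gap, and an amine or a carboxylic acid would test a different kind of substituent.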